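Vero cell cytotoxicity across three measured analogues and one pending

This account rests on a few compounds, and the source may have more. Where it says the series, first, only, none or still open, it means among the compounds named here.

Measured so far:
compound 1, `CN1Cc2ccc(OCc3ccccc3)cc2[C@@H](O)C1`, gives > 100000 nM in an ADME assay on Vero cells (Chlorocebus sabaeus) for cytotoxicity, read by sulforhodamine B assay, with a stated time of 72 h; on this read-out lower numbers stand for stronger inhibition and higher numbers for weaker inhibition
compound 2, `Cc1cccc(COc2ccc3c(c2)[C@@H](O)CN(C)C3)c1`, gives > 50000 nM in this assay
compound 3, `CN1Cc2ccc(OCc3cccc(Br)c3)cc2[C@@H](O)C1`, gives 60300 nM in this assay

The value of compound 1 is a limit of the assay, not a number (the limit of > 100000 nM in this assay, at which 1 of the 3 values shown sits). The value of compound 2 is likewise a limit (the limit of > 50000 nM in this assay, at which 1 of the 3 values shown sits). Only compound 3 gives a number. Within the data shown here, the step of an at least 1.6-fold lower number from compound 1 to compound 3 (0.21 log units; that floor lies within the scatter) is the one readable step, and its floor lies within the scatter; the step that the two limits leave unreadable from compound 1 to compound 2 and the step that the limit leaves unreadable from compound 2 to compound 3 cannot be sized from limits.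

Compound 4, `CN1Cc2ccc(OCc3ccc(-c4ccc(Cl)cc4)cc3)cc2[C@@H](O)C1`, differs from compound 1 by 4-chlorophenyl in place of hydrogen on an aromatic carbon. Among the measured compounds shown here, the only bearing step is the one from compound 1 to compound 3, a substituent entering the same ring and lowering the number by no more than scatter allows. A larger group enters here, so a modestly lower number is expected, with a real chance the assay again reports only a limit. Compound 4 is estimated at 40000 nM (range 12000 nM to 100000 nM), which means an expected step of an at least 2.5-fold lower number from compound 1 to compound 4 (0.39 log units; beyond the scatter).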

Compound 4, half-maximal inhibitory concentration: 21700 nM
Estimate against measurement, compound 4: 1.8-fold (0.27 log units) above; the measured number falls inside the stated range.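

In this assay, 4-chlorophenyl on an aromatic carbon, para to a large group, gives an at least 4.6-fold lower number from compound 1 to compound 4 (0.66 log units; beyond the scatter), whereas the earlier readable step, an at least 1.6-fold lower number from compound 1 to compound 3 (0.21 log units; that floor lies within the scatter), could not be told from scatter. This is therefore the first change in the series shown to lower the number beyond the scatter, and a substituent of this size at this place still leaves a measurable value rather than a limit. The step remains a floor because the value of compound 1 is a limit of the assay: the limit of > 100000 nM in this assay, at which 1 of the 4 values shown sits.

The compounds shown leave open whether the step follows the added aromatic ring or its chlorine, which a plain phenyl group at the same place would separate. They also leave open whether a carboxylic acid or a morpholine at this place would move the number in the same direction.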